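This account rests on a few compounds, and the source may have more. Where it says the series, first, only, none or still open, it means among the compounds named here.

Of the compounds shown here, three built on one shared core have been tested in a functional assay on KBVIN cells (Homo sapiens) for antiproliferative activity, read by sulforhodamine B assay, with a stated time of 72 h; a higher number here means a weaker inhibitor of growth, a lower number a stronger inhibitor of growth. Compound 1 `Cc1cc(=O)oc2cc(SCc3ccncc3)ccc12` gives only a limit in this assay, namely > 35200 nM, so no number is known for it. Compound 2 `Cc1cc(=O)oc2cc(SCc3cccc(C(F)(F)F)c3)ccc12` likewise gives only a limit in this assay, > 28500 nM. Compound 3 `Cc1cc(=O)oc2cc(SCc3cccc(C#N)c3)ccc12` too gives only a limit in this assay, > 32500 nM. Where compound 3 stands is thus known only as a limit, and the two further values shown are limits as well. Among the measured compounds shown here, the single step between measured compounds that differ in one place, a step that the two limits leave unreadable from compound 2 to compound 3, cannot be read, since both ends sit at limits; this rests on (the limit of > 28500 nM in this assay, at which 1 of the 3 values shown sits), the limit of > 32500 nM in this assay, at which 1 of the 3 values shown sits, and (the limit of > 35200 nM in this assay, at which 1 of the 3 values shown sits).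

The change now followed, (methyl in place of cyano on an aromatic carbon), methyl in place of cyano on an aromatic carbon, meta to a large group, turns compound 3 into compound 4 `Cc1cccc(CSc2ccc3c(C)cc(=O)oc3c2)c1`. For the measured compounds named here, the only measured step, a step that the two limits leave unreadable from compound 2 to compound 3, is unreadable in size, so no readable step bears on this change, and no direction beyond the scatter can be derived from it. With all three measured values sitting at limits, the expected step that the limit leaves unreadable from compound 3 to compound 4 is taken as none beyond the scatter, and a limit rather than a number is the likely outcome. For compound 4 the estimated value in this assay is 40000 nM, within a range from 15000 nM to 120000 nM.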

Compound 4, concentration for 50% growth inhibition: > 33700 nM
Compound 4 gave a limit, no number (the forecaster's own chance of this, stated with the estimate: 80%); the middle value lies beyond the limit too.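

Compound 4 gives only a limit in this assay, > 33700 nM. Its steps from compound 1, compound 2 and compound 3 cannot be read, because both ends of each step sit at limits: the limit of > 33700 nM in this assay, at which 1 of the 4 values shown sits.

The compounds shown leave open how strongly any of them inhibits growth, and whether swapping these groups changes that at all.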